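The compounds below may be only part of what the source reports. "The series", "measured", "known", "first", "only" and "open" are said of these compounds alone.

Measured so far:
Compound 1, `Nc1nc(-c2ccc(Cl)cc2)c(CC(=O)O)s1`, gives > 100000 nM, which is a limit of the assay and not a number.
Compound 2, `CS(=O)(=O)Nc1cccc(-c2nc(C(c3ccc(F)cc3)c3ccc(F)cc3)sc2CC(=O)O)c1`, gives 40 nM.

Both values come from an in vitro assay on HEK385-7 cells for displacement of a labelled ligand from prostaglandin D2 receptor 2 (Homo sapiens); a higher number here means a weaker inhibitor, a lower number a stronger inhibitor. For the measured compounds named here, compound 2 thus stands as the only compound with a measured number; the one other value sits at the limit of > 100000 nM in this assay, at which 1 of the 2 values shown sits. The next compound, compound 3, `O=C(O)Cc1sc(C(c2ccc(F)cc2)c2ccc(F)cc2)nc1-c1ccnc(O)c1`, has not yet been measured. It differs from compound 2 in one place: 2-hydroxypyridin-4-yl in place of 3-(methanesulfonamido)phenyl on an aromatic carbon. The group that enters has fewer heavy atoms than the group that leaves, and its ring carries a hetero atom. Going by the values given here, no measured pair shows a change of this kind, so the size of the step in this assay can only be estimated; a modest weakening, somewhat beyond the usual scatter, seems most likely. The estimated step is a 3.0-fold higher number from compound 2 to compound 3 (0.48 log units; beyond the scatter). Compound 3 is therefore expected to give about 120 nM, with a likely range from 30 nM to 500 nM.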

Compound 3, half-maximal inhibitory concentration: 68 nM
Estimate against measurement, compound 3: 1.8-fold (0.25 log units) above; the measured number falls inside the stated range.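

In this assay, replacing the group on the aromatic carbon next to the ring nitrogen gives a 1.7-fold higher number from compound 2 to compound 3 (0.23 log units; within the scatter) for this change. Within this pair, the 3-(methanesulfonamido)phenyl group with 11 heavy atoms can therefore give way to the 2-hydroxypyridin-4-yl group with 7, whose ring carries a hetero atom, with no shift beyond the scatter. Nothing measured here accounts for this outcome.

The compounds shown leave open whether the hydroxyl on the new ring matters, which a 2-methoxypyridin-4-yl or a plain pyridin-4-yl group at this position would test. They also leave open how a phenyl ring carrying only an amine would compare in this assay with the two groups seen so far.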